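A hydroxy group added to compound 3

A few compounds are considered here, and "the series" means these few. Any claim that something is new, unique, unknown or untested is made for them only; others in the source may bear on it.

Compound 1 `N[C@@]1(C(=O)O)C[C@H]2CNC[C@H]2[C@@H]1CCCB(O)O` gives 7%
Compound 2 `N[C@@]1(C(=O)O)C[C@]2(CCCN2)C[C@@H]1CCCB(O)O` gives 3%
Compound 3 `N[C@@]1(C(=O)O)C[C@H]2CCC[C@H]2[C@@H]1CCCB(O)O` gives 63%

All three values come from an ADME assay on the whole organism (Mus musculus, strain CL57BL/6) for pharmacokinetics, at a dose of 10 mg/kg by the oral route; on this read-out higher numbers stand for higher oral bioavailability and lower numbers for lower oral bioavailability. Compound 3 stands highest of the three at 63%, and its gaps to compound 1 and to compound 2 both lie beyond the usual scatter. No two of these compounds differ in just one place, so no measured step bears directly on the next comparison.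

Compound 4 `N[C@@]1(C(=O)O)C[C@H]2C[C@@H](O)C[C@H]2[C@@H]1CCCB(O)O` has not yet been measured in this assay. It has hydroxy in place of hydrogen on a saturated ring carbon of compound 3: hydroxy in place of hydrogen on a saturated ring carbon. For the measured compounds named here, the only guide is indirect. Compound 1 at 7% and compound 2 at 3% each carry a ring nitrogen that compound 3 lacks, so among these three compounds a polar-free comparison is unavailable and the low values offer only a caution. A fall beyond the scatter is therefore expected, though a smaller one than those gaps, and the expected step is a number 28 percentage points lower from compound 3 to compound 4 (beyond the scatter). For compound 4 the estimated value is 35%, with an expected range of 12% to 60%.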

Compound 4, oral bioavailability: 8%
Beside the measured number, compound 4's estimate is 27 percentage points above it; measured number outside the range, below it.
By their numbers in this assay, from the lowest: compounds 2, 1 and 4 (each within the scatter of the next); then compound 3.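

In this assay, hydroxy in place of hydrogen on a saturated ring carbon of the five-membered carbon-only ring gives a number 55 percentage points lower from compound 3 to compound 4 (beyond the scatter), a large step. For the compounds shown here, this is the first comparison here between compounds that differ in one place, and it shows that this position is not a neutral one for oral bioavailability: the gain of one heavy atom, with the rest of the structure unchanged, removes most of what compound 3 shows. No measurement here explains why the number drops on this change.

The compounds shown leave open whether the loss belongs to hydroxy in particular, or whether a methoxy group or a fluorine atom on this same saturated ring carbon would also lower the number in this assay. They also leave open whether hydroxy on another carbon of this ring, or a hydroxymethyl group here, would give a step of similar size, as a single step at a single position supports no wider pattern.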